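The compounds below may be only part of what the source reports. "The series", "measured", "known", "first", "only" and "open" are said of these compounds alone.

Measured so far in an ADME assay on L929 cells (Mus musculus) for cytotoxicity; on this read-out higher numbers stand for weaker inhibition and lower numbers for stronger inhibition
compound 1 `O=[N+]([O-])c1cn2c(n1)OC[C@@H](NCc1ccc(OC(F)(F)F)cc1)C2` gives > 10 ug/mL as a limit
compound 2 `O=[N+]([O-])c1cn2c(n1)OCC(COc1ccc(-c3ccc(OC(F)(F)F)cc3)nc1)C2` gives > 10 ug/mL as a limit
compound 3 `O=[N+]([O-])c1cn2c(n1)[S@+]([O-])C[C@H](OCc1ccc(OC(F)(F)F)cc1)C2` gives > 10 ug/mL as a limit

Within the data shown here, compound 3 stands on a limit and not on a number, with the limit of > 10 ug/mL in this assay, at which 3 of the 3 values shown sit, as the only evidence. Among the measured compounds shown here, compound 4 `O=[N+]([O-])c1cn2c(n1)[S@@+]([O-])C[C@@H](OCc1ccc(OC(F)(F)F)cc1)C2` shows the two compounds have the same atoms and bonds and differ only in configuration as drawn: 2 of 2 stereo elements differ (all stereocentres are inverted: mirror images); a stereocentre at a sulfur is drawn R in compound 3 and S in compound 4; a stereocentre at a saturated ring carbon is drawn R in compound 3 and S in compound 4 against compound 3, so the two are mirror images, with the stereocentre at sulfur and the stereocentre at the saturated ring carbon each drawn S in place of R. No measured pair isolates configuration, so no step beyond the scatter is expected in this assay and no direction is assumed. The change a step that the limit leaves unreadable from compound 3 to compound 4 is expected to stay within the scatter. Compound 4 is estimated at 16 ug/mL with an expected range of 8 ug/mL to 40 ug/mL and will most likely be reported as a limit again.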

Compound 4, half-maximal inhibitory concentration: > 10 ug/mL
Compound 4: a limit, no number; the forecaster's own chance of this, stated with the estimate: 85%; the middle value is on the limit's open side.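

In this assay no step can be read between compound 3 and compound 4 because both results are limits: the limit of > 10 ug/mL in this assay, at which 4 of the 4 values shown sit.
The compounds shown leave open whether the configuration at sulfur or at the saturated ring carbon has any effect on this read-out.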